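The source may hold more compounds than are shown below. What is called first, only, known or untested is meant among the compounds shown, and "the series" means these compounds.

For the measured compounds named here, in an ADME assay on the whole organism for inhibition, with Echinochloa crus-galli var. formosensis as the target, with a stated time of 4 days (on this read-out higher numbers stand for weaker inhibition and lower numbers for stronger inhibition), compound 1 `CC(C)N(c1nc(Cl)nc(N[C@H](C)c2ccccc2)n1)C(C)C` gives 6610 nM, the lowest of the three numbers so far. Compound 2 `CCNc1nc(Cl)nc(NC(C)c2ccccc2)n1` gives 9770 nM, within the scatter of compound 1, while compound 3 `CCNc1nc(Cl)nc(N[C@@H](C)c2ccccc2)n1` gives 30900 nM, beyond it. Going by the values given here, the only measured step, a 3.2-fold higher number from compound 2 to compound 3 (0.50 log units; beyond the scatter), turns on the fact that one of compounds 2 and 3 is drawn with a defined configuration and the other without, at the place where they differ and says nothing about the amino group examined here. Compound 4 `CCCNc1nc(Cl)nc(N[C@H](C)c2ccccc2)n1` differs from compound 1 by propylamino in place of diisopropylamino on an aromatic carbon. Among the compounds with values here, no measured step covers such an exchange; the values of compound 1 and compound 2, which carry different amino groups at that place, lie within the scatter of each other. A step of a 1.2-fold higher number from compound 1 to compound 4 (0.08 log units; within the scatter) is therefore expected, not beyond the scatter. Compound 4 is estimated at 8000 nM, ranging from 3000 nM to 25000 nM.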

Compound 4, half-maximal inhibitory concentration: 33100 nM
The estimate for compound 4 lay 4.1-fold (0.62 log units) below the measured number; measured number outside the range, above it.
By their numbers in this assay, from the lowest: compounds 1 and 2 (each within the scatter of the next); then compounds 3 and 4 (each within the scatter of the next).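

In this assay, the amino group on this aromatic carbon proves able to shift the read-out: with propylamino in place of diisopropylamino, inhibition weakens (a 5.0-fold higher number from compound 1 to compound 4 (0.70 log units; beyond the scatter)). The exchange removes heavy atoms and adds a hydrogen-bond donor, and this single pair cannot separate those two differences. Nothing measured here bears on the reason for this step. As far as these compounds go, whether a dimethylamino or a butylamino group at this place would give a number closer to that of compound 1 or compound 4 remains open.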